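Halophenyl versus thienyl on the fused core: compound 4

The source may report more compounds than this note shows. Statements on the series, on what has been measured and on what is new or still open speak of the compounds shown alone.

Measured so far in a functional assay on SF-539 cells (Homo sapiens) for inhibition, read by sulforhodamine B assay, with a stated time of 48 h, tested at 10 uM; on this read-out higher numbers stand for more inhibition at the one concentration tested (going by the name of the read-out) and lower numbers for less inhibition:
compound 1 `c1ccc(-c2cn3ccnc3c(-c3ccc4ncn(C5CCCCC5)c4c3)n2)cc1` — 27.8%
compound 2 `Fc1ccc(-c2cn3ccnc3c(-c3ccc4ncn(C5CCCCC5)c4c3)n2)cc1` — 17.3%
compound 3 `c1cn2cc(-c3ccsc3)nc(-c3ccc4ncn(C5CCCCC5)c4c3)c2n1` — 6.29%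

Compound 3 stands lowest of the three, beyond the scatter below both compound 2 and compound 1. Compound 4 `Brc1ccc(-c2cn3ccnc3c(-c3ccc4ncn(C5CCCCC5)c4c3)n2)cc1` differs from compound 3 by 4-bromophenyl in place of thiophen-3-yl on an aromatic carbon. The step from the 4-fluorophenyl compound to the thienyl compound, a number 11 percentage points lower from compound 2 to compound 3 (beyond the scatter), and the step from the phenyl compound, a number 21.5 percentage points lower from compound 1 to compound 3 (beyond the scatter), both bear on this; reversing the ring change should therefore recover a modest gain in this assay. For the measured compounds named here, no measured step separates bromo from fluoro on the phenyl ring, so that part is uncertain. Compound 4 is expected to give about 18%, range 6% to 32%, an estimated rise of a number 11.7 percentage points higher from compound 3 to compound 4 (beyond the scatter).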

Compound 4, a percentage reported as inhibition, at one concentration (the size of the read-out at that concentration, not a potency): 24.4%
Compound 4: the middle estimate sits 6.4 percentage points below what was measured; low and high end bracket the measured number.
By their numbers in this assay, from the lowest: compound 3; then compounds 2, 4 and 1 (each within the scatter of the next, the first and the last beyond it).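

In this assay, the 4-bromophenyl group separates clearly from thiophen-3-yl (a number 18.1 percentage points higher from compound 3 to compound 4 (beyond the scatter)), so compound 3 now lies beyond the scatter below compound 1 and compound 4 as well. Bromo cannot be told apart from fluoro (a number 7.1 percentage points higher from compound 2 to compound 4 (within the scatter)) or from hydrogen (a number 3.4 percentage points lower from compound 1 to compound 4 (within the scatter)), although compound 1 and compound 2 do stand apart. No measured property bears on these differences.

Still open, on these data alone, is whether a 4-methoxyphenyl, a 4-aminophenyl or a furan-3-yl group at this position would stay with compound 4 or fall towards compound 3.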